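This account rests on a few compounds, and the source may have more. Where it says the series, first, only, none or still open, it means among the compounds named here.

The set gathers three compounds measured in a functional assay on L1210 cells (Mus musculus) for antiproliferative activity, read by cell counting, with a stated time of 2 days (a higher number here means a weaker inhibitor, a lower number a stronger inhibitor), and one awaiting measurement. Compound 1, `COc1ccc(Nc2nc(N)c(C(=O)c3ccc(OC)c(OC)c3)s2)cc1`, gives 38 nM in this assay. Compound 3, `COc1ccc(Nc2nc(N)c(C(=O)c3cc(OC)c(OC)c(OC)c3)s2)cc1`, gives 1500 nM. Compound 2, `COc1ccccc1C(=O)c1sc(Nc2ccccc2)nc1N`, gives 1100 nM. Compound 4, `COc1ccc(Nc2nc(N)c(C(=O)c3ccccc3OC)s2)cc1`, has not yet been measured.

Two of the pairs share one kind of change. From compound 1 to compound 3 the difference is methoxy in place of hydrogen on an aromatic carbon, and the step it made was a 39-fold higher number from compound 1 to compound 3 (1.60 log units; beyond the scatter). From compound 2 to compound 4 the difference is methoxy in place of hydrogen on an aromatic carbon. The two changes are the same kind but not the same: in compound 3 the entering group sits ortho to a methoxy group, meta to a large group and meta to a methoxy group, whereas in compound 4 it sits para to a large group on a ring that carries no other group. The difference between the cores of compound 2 and compound 1 is not broken down here; their values in this assay simply stand far apart, with compound 2 the higher of the two.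

Because the earlier step of a 39-fold higher number from compound 1 to compound 3 (1.60 log units; beyond the scatter) was made at a different place, it offers only a loose guide. The step from compound 2 to compound 4 in this assay is expected to be a 1.6-fold lower number from compound 2 to compound 4 (0.20 log units; within the scatter). Compound 4 is estimated at 700 nM, with an expected range from 150 nM to 3000 nM.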

Compound 4, half-maximal inhibitory concentration: 31 nM
Compound 4: the middle estimate sits 23-fold (1.35 log units) above what was measured, and the stated range ends above it.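

In this assay, methoxy entering in place of hydrogen on an aromatic carbon, para to a large group, as phenyl becomes 4-methoxyphenyl, gave a 35-fold lower number from compound 2 to compound 4 (1.55 log units; beyond the scatter) and thus a marked gain in potency on this core. The same kind of change, made at a different place on the ring of another core, moved the number the opposite way, and the two steps differ by more than the scatter allows, which shows that neither the size nor the direction of a methoxy step can be carried from one core to the other in this series: the same change on two cores in this assay, a 39-fold higher number (1.60 log units; beyond the scatter) from compound 1 to compound 3 and a 35-fold lower number (1.55 log units; beyond the scatter) from compound 2 to compound 4, 1400-fold (3.15 log units) apart, beyond the scatter of two such steps. What this does not show is why the two steps part, since they differ both in the core and in where the methoxy enters, and a single pair on each side cannot separate those two differences or support a rule for other compounds.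

The compounds shown leave open whether the step from compound 2 to compound 4 belongs to methoxy itself or would also appear with an ethoxy group, a hydroxyl group or a chlorine atom at the same place. They also leave open how the same para change would behave on a ring that already carries other groups, and whether methoxy at the other ring positions on this core would give a step of similar size.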